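The source may report more compounds than this note shows. Statements on the series, on what has been measured and on what is new or still open speak of the compounds shown alone.

The measured compounds:
- compound 1, `CCOC(=O)Cn1cc(-c2ccc3ccccc3c2)nn1`: in a functional assay on B16 cells (Mus musculus) for cytotoxicity, read by MTT assay, with a stated time of 48 h (on this read-out lower numbers stand for stronger inhibition and higher numbers for weaker inhibition), compound 1 gives > 100000 nM, a limit of the assay rather than a number.
- compound 2, `COc1ccc(C(O)c2cn(C[C@H]3COC(C)(C)O3)nn2)cc1`: in this assay compound 2 gives > 100000 nM, likewise a limit of the assay.

On the numbers shown, compound 1 stands at a limit only, and the one further value is also a limit, so nothing separates the two: the limit of > 100000 nM in this assay, at which 2 of the 2 values shown sit. Compound 3, `c1ccc(Cn2cc(-c3ccc4ccccc4c3)nn2)cc1`, differs from compound 1 by phenyl in place of ethoxycarbonyl on a saturated chain carbon bound to an aromatic nitrogen. For the measured compounds named here, no step between measured compounds is available for this change, and the two measured values show only that neither reaches a number in this assay. The step expected from this change is an at least 1.2-fold lower number from compound 1 to compound 3 (0.09 log units; that floor lies within the scatter), with no direction beyond the scatter. For compound 3 the estimate in this assay is 80000 nM, ranging from 20000 nM to 200000 nM, and most likely it is again reported as a limit.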

Compound 3, half-maximal inhibitory concentration: 3890 nM
Estimate against measurement, compound 3: 21-fold (1.31 log units) above, and the stated range ends above it.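

In this assay, phenyl in place of ethoxycarbonyl on a saturated chain carbon bound to an aromatic nitrogen gives an at least 25-fold lower number from compound 1 to compound 3 (1.41 log units; beyond the scatter). The earlier compounds shown here stayed at a limit of the assay and could not show that this position responds at all; the change from (ethoxycarbonyl)methyl to benzyl now shows that it does. Compound 3 is the only one of the three compounds that gives a number rather than a limit: the limit of > 100000 nM in this assay, at which 2 of the 3 values shown sit.

The compounds shown cannot separate a gain brought by phenyl from a loss of ethoxycarbonyl as the source of this step. From the compounds shown here alone, it also remains open whether a longer chain carrying the phenyl ring, or an amine or a carboxylic acid at this position, would give a number in this assay.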